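From 4-chlorophenyl to 3-chlorophenyl in the series

A few compounds are considered here, and "the series" means these few. Any claim that something is new, unique, unknown or untested is made for them only; others in the source may bear on it.

In a physicochemical assay for solubility, read by nephelometry, measured as kinetic solubility, at pH 6.5 (a lower number here means a less soluble compound, a higher number a more soluble compound), compound 3 `Cn1c(-c2ccc(Cl)cc2)cnc1NC(=O)c1ncc[nH]1` gives 25 ug/mL. Compound 2 `Cn1c(-c2ccccc2)cnc1NC(=O)c1ccc(F)cc1` gives 25 ug/mL, the same number at the digits shown, while compound 1 `COc1ccc(-c2cnc(NC(=O)c3ncc[nH]3)n2C)cc1` gives a lower 6.3 ug/mL. Compound 3 therefore sits level with compound 2 at the top of this small set.

Compound 4 `Cn1c(-c2cccc(Cl)c2)cnc1NC(=O)c1ncc[nH]1` has the same atoms as compound 3, joined differently: 3-chlorophenyl in place of 4-chlorophenyl on an aromatic carbon. The group sits on an aromatic carbon of a five-membered aromatic ring with 2 nitrogen.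

Among the compounds with values here, one measured step bears on this change: a 4.0-fold higher number from compound 1 to compound 3 (0.60 log units; beyond the scatter). That step is modest and beyond the scatter, but it swaps methoxy for chloro on an aromatic carbon and does not move a group. Within the data shown here, no measured pair tests a shift of the chlorine, so the data set no direction. The expected step is no change at the digits printed from compound 3 to compound 4 (within the scatter), with nothing expected beyond the scatter in this assay. For compound 4 the estimated value is 25 ug/mL, with an expected range of 9 ug/mL to 60 ug/mL.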

Compound 4, solubility: 3.1 ug/mL
For compound 4 the middle estimate is 8.1-fold (0.91 log units) above the measured one, outside the stated range (below it).
By their numbers in this assay, from the lowest: compound 4; then compound 1; then compounds 2 and 3 (each within the scatter of the next).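

In this assay, the step is an 8.1-fold lower number from compound 3 to compound 4 (0.91 log units; beyond the scatter), so moving the chlorine with no change in atoms is enough to take the number beyond the scatter. Within the data shown here, the earlier compounds showed only an exchange of one group for another on the phenyl ring, and this pair is the first to test the placing of a group there. No measurement on hand explains the step, so it stands as an observation on this one pair.

A single pair cannot show whether the step belongs to chlorine alone or would recur with 3-methoxyphenyl set against the 4-methoxyphenyl of compound 1. As far as these compounds go, how 2-chlorophenyl, or an amine or a carboxylic acid on the phenyl ring, would read in this assay also remains open.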